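Piperidine carboxamide series, ring-nitrogen substituent and in vivo antagonism

The source may report more compounds than this note shows. Statements on the series, on what has been measured and on what is new or still open speak of the compounds shown alone.

Compound 1 `CCCCCCCN1CCC(C(=O)Nc2cc(Cl)c(N)cc2OC)CC1`, compound 2 `COc1cc(N)c(Cl)cc1NC(=O)C1CCN(C2CCCC2)CC1` and compound 3 `COc1cc(N)c(Cl)cc1NC(=O)C1CCN(CC2CC2)CC1` share one core and differ only in the group carried on the amine nitrogen in the ring. In a functional assay on the whole organism for antagonist activity, with Mus musculus as the target (a lower number here means that less compound is needed, a higher number that more compound is needed for the effect), compound 1 gives only a limit, > 10 mg/kg. In this assay compound 2 likewise gives only a limit, > 10 mg/kg. In this assay compound 3 also gives only a limit, > 10 mg/kg. Compound 3 thus stands at the limit of > 10 mg/kg in this assay, at which 3 of the 3 values shown sit, with no number to place it against the others. The steps a step that the two limits leave unreadable from compound 1 to compound 2, a step that the two limits leave unreadable from compound 1 to compound 3 and a step that the two limits leave unreadable from compound 2 to compound 3 are all of unreadable size. Compound 4 `COc1cc(N)c(Cl)cc1NC(=O)C1CCN(Cc2ccc(Cl)cc2)CC1` differs from compound 3 by 4-chlorophenyl in place of cyclopropyl on a saturated chain carbon bound to an amine nitrogen in a ring. Going by the values given here, no measured step gives a readable guide for this change, as every value so far is a limit. Compound 4 is expected to sit near the same limit, estimated at 8 mg/kg, within 2 mg/kg to 30 mg/kg. The expected step of an at least 1.2-fold lower number from compound 3 to compound 4 (0.09 log units; that floor lies within the scatter) is accordingly small.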

Compound 4, dose for half-maximal effect: 1.2 mg/kg
The estimate for compound 4 lay 6.7-fold (0.82 log units) above the measured number; measured number outside the range, below it.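

Of the groups on the amine nitrogen in the ring, only 4-chlorobenzyl gives a readable number in this assay, while the other three compounds remain at a limit: the limit of > 10 mg/kg in this assay, at which 3 of the 4 values shown sit.

Replacing cyclopropylmethyl gives an at least 8.3-fold lower number from compound 3 to compound 4 (0.92 log units; beyond the scatter), replacing cyclopentyl gives an at least 8.3-fold lower number from compound 2 to compound 4 (0.92 log units; beyond the scatter), and replacing heptyl gives an at least 8.3-fold lower number from compound 1 to compound 4 (0.92 log units; beyond the scatter). The steps among compound 1, compound 2 and compound 3 cannot be read.

As far as these compounds go, whether the change depends on the chlorine or on the aromatic ring stays open, and plain benzyl would separate the two. From the compounds shown here alone, the effect of a longer link to that ring, as in 2-(4-chlorophenyl)ethyl, also stays open.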